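Hydroxy to Methoxy: Estimating Compound 4

The source may hold more compounds than are shown below. What is called first, only, known or untested is meant among the compounds shown, and "the series" means these compounds.

Measured in a functional assay on OVCAR-3 cells (Homo sapiens) for inhibition, read by MTT assay, with a stated time of 24 h; on this read-out higher numbers stand for weaker inhibition and lower numbers for stronger inhibition:
Compound 1 `CC1(C)[C@H]2CC[C@]1(C)N(Cc1cn(-c3ccccc3Br)nn1)C(=O)C2`: 140 nM
Compound 2 `CC1(C)[C@H]2CC[C@]1(C)N(Cc1cn(-c3ccc(F)cc3)nn1)C(=O)C2`: 200 nM
Compound 3 `CC1(C)[C@H]2CC[C@]1(C)N(Cc1cn(-c3cccc(O)c3)nn1)C(=O)C2`: 370 nM

Compound 3 gives the highest of the three numbers. One step leading to it, a 2.6-fold higher number from compound 1 to compound 3 (0.42 log units; beyond the scatter), lies beyond the scatter, while the other, a 1.9-fold higher number from compound 2 to compound 3 (0.27 log units; within the scatter), falls within the scatter. Compound 4 `COc1cccc(-n2cc(CN3C(=O)C[C@@H]4CC[C@@]3(C)C4(C)C)nn2)c1` differs from compound 3 by methyl in place of hydrogen on an oxygen on an aromatic ring. Going by the values given here, no measured step concerns a hydroxy or methoxy group directly; the three aryl substituent swaps moved the number only modestly, with a 1.4-fold higher number from compound 1 to compound 2 (0.15 log units; within the scatter) the smallest. A step of no more than the scatter is therefore expected, as a 1.1-fold higher number from compound 3 to compound 4 (0.03 log units; within the scatter). Compound 4 is estimated at 400 nM, between 200 nM and 800 nM.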

Compound 4, half-maximal inhibitory concentration: 280 nM
Compound 4: the middle estimate sits 1.4-fold (0.15 log units) above what was measured; the range from low to high includes it.
By their numbers in this assay, from the lowest: compounds 1, 2, 4 and 3 (each within the scatter of the next, the first and the last beyond it).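

In this assay the hydrogen on this oxygen can give way to methyl with only a 1.3-fold lower number from compound 3 to compound 4 (0.12 log units; within the scatter), so on this read-out a free hydroxy is not required to stay in this range. The methoxy compound also stays within the scatter of the other two aryl compounds, with a 1.4-fold higher number from compound 2 to compound 4 (0.15 log units; within the scatter) and a 2.0-fold higher number from compound 1 to compound 4 (0.30 log units; within the scatter). No measurement shown here offers an explanation for this result.

Still open, from the compounds shown here alone, is whether a longer chain on this oxygen, as in ethoxy, would keep the number in this range. An amine in place of the hydroxy is equally untested among the compounds shown.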